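The compounds below may be only part of what the source reports. "The series", "measured", "known", "first", "only" and "open" are said of these compounds alone.

Compound 3 `Cc1cccc(C(=O)Nc2cccc(-c3oc4cc(-c5ccc(F)cc5)ccc4c(=O)c3O)c2)c1` stands second highest among the three measured compounds in a functional assay on MCF7 cells (Homo sapiens) for antiproliferative activity, read by CCK-8 assay, with a stated time of 72 h (on this read-out higher numbers stand for weaker inhibition and lower numbers for stronger inhibition), with compound 3 giving 7850 nM. Its nearest neighbour is compound 1 `O=C(Nc1cccc(-c2oc3cc(-c4ccc(F)cc4)ccc3c(=O)c2O)c1)c1ccc(F)cc1`, which gives 8590 nM; the step of a 1.1-fold lower number from compound 1 to compound 3 (0.04 log units; within the scatter) lies within the scatter. The furthest is compound 2 `Cc1ccccc1C(=O)Nc1cccc(-c2oc3cc(-c4ccc(F)cc4)ccc3c(=O)c2O)c1`, which gives 2280 nM, and the step of a 3.4-fold higher number from compound 2 to compound 3 (0.54 log units; beyond the scatter) is beyond the scatter. Compound 4 `CCc1ccc(C(=O)Nc2cccc(-c3oc4cc(-c5ccc(F)cc5)ccc4c(=O)c3O)c2)cc1` differs from compound 3 by 4-ethylphenyl in place of 3-methylphenyl on a carbonyl carbon. Among the compounds with values here, no measured step introduces a 4-ethylphenyl group, so only indirect bearing exists: swapping the 4-fluorophenyl of compound 1 for 3-methylphenyl gave a 1.1-fold lower number from compound 1 to compound 3 (0.04 log units; within the scatter), while the move to 2-methylphenyl gave a 3.8-fold lower number from compound 1 to compound 2 (0.58 log units; beyond the scatter). Among these, only the 2-methylphenyl change moved the number beyond the scatter; the other aryl exchange did not. Compound 4 is therefore expected to show a 1.1-fold lower number from compound 3 to compound 4 (0.05 log units; within the scatter), a step not beyond the scatter. The estimate for compound 4 in this assay is 7000 nM, ranging from 2500 nM to 20000 nM.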

Compound 4, half-maximal inhibitory concentration: 22800 nM
Compound 4: the middle estimate sits 3.3-fold (0.51 log units) below what was measured, outside the stated range (above it).
By their numbers in this assay, from the lowest: compound 2; then compounds 3 and 1 (each within the scatter of the next); then compound 4.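

Within the data shown here, compound 4 is the first compound here to show that a change on this aryl group can raise the number beyond the scatter, with a 2.9-fold higher number from compound 3 to compound 4 (0.46 log units; beyond the scatter) in this assay on exchanging 3-methylphenyl for 4-ethylphenyl on the carbonyl carbon. Until now the only shift beyond the scatter had come from 2-methylphenyl, but ethyl in place of fluoro on an aromatic carbon gives a 2.7-fold higher number from compound 1 to compound 4 (0.42 log units; beyond the scatter) and places compound 4 highest of the series, while the exchange of 2-methylphenyl for 4-ethylphenyl gives a 10-fold higher number from compound 2 to compound 4 (1.00 log units; beyond the scatter) as the widest span at this position. No evidence is available that explains these differences.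

The compounds shown leave open whether a longer chain such as propyl would raise the number further than ethyl does. They also leave open how an amine or a carboxylic acid in place of ethyl would read in this assay.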